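Trading 4-hydroxyphenyl for 3-chlorophenyl on the chain

A few compounds are considered here, and "the series" means these few. Any claim that something is new, unique, unknown or untested is made for them only; others in the source may bear on it.

In a functional assay on PANC-1 cells (Homo sapiens) for cytotoxicity, read by WST assay, with a stated time of 24 h (on this read-out higher numbers stand for weaker inhibition and lower numbers for stronger inhibition), compound 3 (`O=C(CCCCCCCCc1ccc(O)cc1)N1CCCCC1`) gives > 100000 nM and this is a limit of the assay, not a number. Compound 1 (`O=C(/C=C/CCCCCCc1ccccc1)NCc1ccccc1`) gives > 100000 nM and that too is a limit. Compound 2 (`O=C(CCCCCCCCc1ccc(C(F)(F)F)cc1)N1CCCCC1`) gives 54000 nM as an actual number. Compound 4 (`O=C(CCCCCCCCc1cccc(Cl)c1)N1CCCCC1`) carries 3-chlorophenyl in place of 4-hydroxyphenyl on a saturated chain carbon, eight bonds along the chain from a carbonyl carbon. Going by the values given here, one measured step bears on this change: an at least 1.8-fold higher number from compound 2 to compound 3 (0.26 log units; that floor lies within the scatter) when hydroxy replaced trifluoromethyl on an aromatic carbon. That step offers only weak guidance, and it points to a modestly lower number once hydroxy leaves. A size of an at least 1.6-fold lower number from compound 3 to compound 4 (0.22 log units; that floor lies within the scatter) is expected in this assay on this basis. Compound 4 is estimated at 60000 nM with an expected range from 25000 nM to 100000 nM in this assay.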

Compound 4, half-maximal inhibitory concentration: > 100000 nM
Compound 4 gave a limit, no number; the forecaster's own chance of this, stated with the estimate: 35%; middle value at least 1.6-fold (0.22 log units) from the limit.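

No step can be read between compound 3 and compound 4 because both stand at a limit rather than a number: the limit of > 100000 nM in this assay, at which 3 of the 4 values shown sit.

Going by these compounds, whether 3-chlorophenyl and 4-hydroxyphenyl differ at all in this assay stays open.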